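Opening a Hydroxylated Ring into a Hydroxypentyl Chain

The source may report more compounds than this note shows. Statements on the series, on what has been measured and on what is new or still open speak of the compounds shown alone.

Compound 1 `CC(C)(C)OC(=O)NCCNC(=O)CN1CN(c2ccccc2)C2(CCN(C(=O)c3ccc(C(C)(C)C)cc3)CC2)C1=O`: 10900 nM
Compound 2 `CC(C)(C)c1ccc(C(=O)N2CCC3(CC2)C(=O)N(CC(=O)NCN)CN3c2ccccc2)cc1`: 26500 nM
Compound 3 `CC(C)(C)c1ccc(C(=O)N2CCC3(CC2)C(=O)N(CC(=O)N2CCCC(O)C2)CN3c2ccccc2)cc1`: 12200 nM

These three compounds share one core and differ only in the group attached to a carbonyl carbon; all were tested in an assay on HEK293 cells for displacement of a labelled ligand from NPC1-like intracellular cholesterol transporter 1 (Homo sapiens); on this read-out higher numbers stand for weaker inhibition and lower numbers for stronger inhibition. Compound 3 holds the second highest of the three numbers: it sits close to compound 1, as a 1.1-fold higher number from compound 1 to compound 3 (0.05 log units; within the scatter) shows, while compound 2 lies further off, as a 2.2-fold lower number from compound 2 to compound 3 (0.34 log units; beyond the scatter) shows.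

Compound 4 `CC(C)(C)c1ccc(C(=O)N2CCC3(CC2)C(=O)N(CC(=O)NCCCCCO)CN3c2ccccc2)cc1` differs from compound 3 at that same carbonyl carbon by (5-hydroxypentyl)amino in place of 3-hydroxypiperidin-1-yl on a carbonyl carbon. Among the compounds with values here, two measured steps bear on this position. In one, an open-chain amine carrying a tert-butoxycarbonyl-amino group gave nearly the same number as the ring (a 1.1-fold higher number from compound 1 to compound 3 (0.05 log units; within the scatter)). In the other, the short (aminomethyl)amino chain gave a modestly higher number than the ring (a 2.2-fold lower number from compound 2 to compound 3 (0.34 log units; beyond the scatter)). Compound 4 again carries an open chain, now ending in a hydroxyl, so the step is expected to be small, leaning if anything toward a higher number: a 1.1-fold higher number from compound 3 to compound 4 (0.06 log units; within the scatter). Compound 4 is estimated at 14000 nM, with a range from 6000 nM to 35000 nM.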

Compound 4, half-maximal inhibitory concentration: 9400 nM
Compound 4: middle estimate off by 1.5-fold (0.17 log units), on the high side; low and high end bracket the measured number.
By their numbers in this assay, from the lowest: compounds 4, 1 and 3 (each within the scatter of the next); then compound 2.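

Opening the 3-hydroxypiperidin-1-yl ring into the (5-hydroxypentyl)amino chain keeps 7 heavy atoms and moves from 1 hydrogen-bond donor to 2, yet in this assay the result stays within the scatter (a 1.3-fold lower number from compound 3 to compound 4 (0.11 log units; within the scatter)), so at this carbonyl carbon the ring is not needed to hold the number. The hydroxyl-ended chain also matches the tert-butoxycarbonyl-bearing chain (a 1.2-fold lower number from compound 1 to compound 4 (0.06 log units; within the scatter)), while the short amino-ended chain of compound 2 stands apart (a 2.8-fold lower number from compound 2 to compound 4 (0.45 log units; beyond the scatter)), making compound 2 the only one of the four that departs from the others. No measurement at hand explains these numbers.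

Open, on these data alone, is whether a plain pentyl chain, with no terminal hydroxyl, would match compound 4. So is whether a pentyl chain ending in an amine or a carboxylic acid, or a longer chain, would shift the number beyond the scatter.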